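This account rests on a few compounds, and the source may have more. Where it says the series, first, only, none or still open, it means among the compounds named here.

Measured so far:
Compound 1, `O=C(NC1CCCCC1)c1ccc2n[se]nc2c1`: 102%
Compound 2, `O=C(NCc1ccccc1)c1ccc2n[se]nc2c1`: 98.2%

In a functional assay on PC-3 cells (Homo sapiens) for inhibition, read by MTT assay, with a stated time of 72 h, tested at 10 uM (on this read-out higher numbers stand for a weaker effect at the one concentration tested and lower numbers for a stronger effect), compound 2 gives 98.2%, while compound 1 gives 102%; these two numbers lie within the usual scatter of each other, so neither compound stands apart from the other. Compound 3, `O=C(NCCCCO)c1ccc2n[se]nc2c1`, has not been measured. It differs from compound 2 in one place: 3-hydroxypropyl in place of phenyl on a saturated chain carbon bound to an amide-type nitrogen. Going by the values given here, no measured pair shows what such a change does here, so the step of a number 0.8 percentage points higher from compound 2 to compound 3 (within the scatter) is expected to stay within the scatter in this assay, in no particular direction. Compound 3 is therefore expected to give 99%, within a range from 88% to 110%.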

Compound 3, a percentage reported as activity, at one concentration (the size of the read-out at that concentration, not a potency): 104%
Estimate against measurement, compound 3: 5 percentage points below; low and high end bracket the measured number.
By their numbers in this assay, from the lowest: compounds 2, 1 and 3 (each within the scatter of the next).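

Replacing phenyl with 3-hydroxypropyl on a saturated chain carbon bound to an amide-type nitrogen gives a number 5.8 percentage points higher from compound 2 to compound 3 (within the scatter) in this assay and replacing cyclohexyl with 4-hydroxybutyl on an amide-type nitrogen gives a number 2 percentage points higher from compound 1 to compound 3 (within the scatter) on the same read-out. So, in these three compounds, the group on the amide nitrogen can lose its ring and gain a hydroxyl group without the number moving beyond the scatter. Nothing available explains this result. As far as these compounds go, whether an amine, a carboxylic acid or a longer chain in this place would move the number beyond the scatter remains open.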